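From Five Fluorines to One on the Styryl Arm

The compounds below may be only part of what the source reports. "The series", "measured", "known", "first", "only" and "open" are said of these compounds alone.

Three compounds have so far been measured in a functional assay on MCF7 cells (Homo sapiens) for inhibition, read by MTT assay, with a stated time of 48 h, tested at 10 uM; a lower number here means less inhibition of growth, a higher number more inhibition of growth at the concentration tested:

Compound 1 `CN1CC[C@H](c2c(O)cc(O)c3c(=O)cc(/C=C/c4ccccc4)oc23)[C@H](O)C1` gives 8%.
Compound 2 `CN1CC[C@H](c2c(O)cc(O)c3c(=O)cc(/C=C/c4ccc(Cl)cc4)oc23)[C@H](O)C1` gives 10%.
Compound 3 `CN1CC[C@H](c2c(O)cc(O)c3c(=O)cc(/C=C/c4c(F)c(F)c(F)c(F)c4F)oc23)[C@H](O)C1` gives 64%.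

Compound 3 stands highest of the three by a wide margin. The step of a number 56 percentage points higher from compound 1 to compound 3 (beyond the scatter) and the step of a number 54 percentage points higher from compound 2 to compound 3 (beyond the scatter) are both large, whereas the step of a number 2 percentage points higher from compound 1 to compound 2 (within the scatter) lies within the scatter, so compounds 1 and 2 cannot be told apart on these numbers.

Compound 4 `CN1CC[C@H](c2c(O)cc(O)c3c(=O)cc(/C=C/c4cccc(F)c4)oc23)[C@H](O)C1` is the next to be tested. It differs from compound 3 in one place: 3-fluorophenyl in place of 2,3,4,5,6-pentafluorophenyl on a double-bonded chain carbon bound to a double-bonded chain carbon.

The two large steps bear directly on this change, since each swapped a ring carrying no fluorine, or a chlorine in its place, for the ring carrying five fluorines, and each raised growth inhibition strongly. Compound 4 keeps a single fluorine on that ring and so sits nearer in structure to compounds 1 and 2 than to compound 3. Most of the gain is therefore expected to be lost, with a step of a number 46 percentage points lower from compound 3 to compound 4 (beyond the scatter) anticipated from compound 3 to compound 4.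

Compound 4 is accordingly estimated at 18%, with a likely range from 4% to 42%.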

Compound 4, percent growth inhibition at one concentration: 83%
Compound 4: middle estimate off by 65 percentage points, on the low side; measured number above the stated range.
By their numbers in this assay, from the lowest: compounds 1 and 2 (each within the scatter of the next); then compound 3; then compound 4.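

Among these compounds, more fluorines on this ring do not go with more growth inhibition. In this assay, 3-fluorophenyl in place of phenyl gives a step of a number 75 percentage points higher from compound 1 to compound 4 (beyond the scatter), and 3-fluorophenyl in place of 2,3,4,5,6-pentafluorophenyl gives a further step of a number 19 percentage points higher from compound 3 to compound 4 (beyond the scatter), so a single fluorine does not merely hold on to the gain seen with five and is enough to exceed it. The step of a number 73 percentage points higher from compound 2 to compound 4 (beyond the scatter) shows that a halogen on this ring does not by itself bring the gain, with compound 2 going against any such rule, and no measurement at hand explains these differences.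

Compound 2 and compound 4 differ in both the halogen and its name-given place on the ring, so the compounds shown cannot say whether the gain follows fluorine itself or that place. As far as these compounds go, a 3-chlorophenyl, a 4-fluorophenyl or a 3-methoxyphenyl group on the same double-bonded chain carbon would begin to separate these two readings, and whether compound 4 keeps its lead at other concentrations also remains open.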